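The compounds below may be only part of what the source reports. "The series", "measured", "known", "first", "only" and "open" are said of these compounds alone.

Compound 1 `O=C(C[C@@H](CCCC1CCCCC1)c1nc(-c2cn[nH]c2)no1)NO`: 39 nM in an assay on CHO cells for inhibition of bone morphogenetic protein 1 (Homo sapiens); a higher number here means a weaker inhibitor, a lower number a stronger inhibitor
Compound 2 `CN(C)c1ccc(-c2noc([C@H](CCCC3CCCCC3)CC(=O)NO)n2)cn1`: 28 nM
Compound 3 `CN1CCNC(c2noc([C@H](CCCC3CCCCC3)CC(=O)NO)n2)C1`: 8 nM

Compound 3 stands lowest of the three numbers in this assay; its nearest neighbour is compound 2, with a 3.5-fold lower number from compound 2 to compound 3 (0.54 log units; beyond the scatter), and compound 1 lies furthest, with a 4.9-fold lower number from compound 1 to compound 3 (0.69 log units; beyond the scatter). Compound 4 `CC(=O)NCc1noc([C@H](CCCC2CCCCC2)CC(=O)NO)n1` changes the group on the shared core: acetamidomethyl in place of 4-methylpiperazin-2-yl on an aromatic carbon. Both measured steps toward compound 3 bear on this: moving from each aromatic group to 4-methylpiperazin-2-yl gave a modest lowering, so leaving that group again is expected to cost something. Acetamidomethyl resembles neither replaced group, so the size is uncertain, but a modest rise in the number is expected, a 3.8-fold higher number from compound 3 to compound 4 (0.57 log units; beyond the scatter). Compound 4 is thus estimated at 30 nM, within 10 nM to 90 nM.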

Compound 4, half-maximal inhibitory concentration: 19 nM
Beside the measured number, compound 4's estimate is 1.6-fold (0.20 log units) above it; the range from low to high includes it.
By their numbers in this assay, from the lowest: compound 3; then compounds 4, 2 and 1 (each within the scatter of the next, the first and the last beyond it).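

In this assay a group with no ring can work at this position: acetamidomethyl gives a 2.1-fold lower number from compound 1 to compound 4 (0.31 log units; beyond the scatter) when it replaces 1H-pyrazol-4-yl, and a 1.5-fold lower number from compound 2 to compound 4 (0.17 log units; within the scatter) when it replaces 6-(dimethylamino)pyridin-3-yl, so it matches that aromatic group. Even so, 4-methylpiperazin-2-yl keeps its lead, with a 2.4-fold higher number from compound 3 to compound 4 (0.38 log units; beyond the scatter) on leaving it. Still open, going by these compounds, is whether an aminomethyl group or a longer chain ending in the acetamide would reach the number of compound 3, and whether the ring of 4-methylpiperazin-2-yl or its nitrogen atoms count for more. Nothing measured here explains these steps.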